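The compounds below may be only part of what the source reports. "The series", "measured", "known", "first", "only" and "open" are said of these compounds alone.

Working notes on the series. In an assay on isolated protein (Bos taurus) for inhibition of geranylgeranyl transferase type-1 subunit beta (Homo sapiens) (a higher number here means a weaker inhibitor, a lower number a stronger inhibitor), compound 2 `Cn1cncc1C(OCc1ccc(C#N)cc1-c1cccc(Cl)c1)c1ccc(C#N)nc1` gives 8620 nM, which is within the scatter of compound 1 `Cn1cncc1C(OCc1ccc(C#N)cc1-c1ccc(F)c(Cl)c1)c1ccc(C#N)nc1` at 8600 nM. Among the compounds with values here, the only measured step, a 1.0-fold higher number from compound 1 to compound 2 (0.00 log units; within the scatter), is flat. Compound 3 `Cn1cncc1C(OCc1ccc(C#N)cc1-c1cc(F)cc(F)c1)c1ccc(C#N)nc1` differs from compound 2 by 3,5-difluorophenyl in place of 3-chlorophenyl on an aromatic carbon. Within the data shown here, the one step that bears on this change, a hydrogen in place of fluoro on an aromatic carbon, gave no movement, so no shift beyond the scatter is expected in this assay from the two fluorines entering. Compound 3 is therefore estimated at 8600 nM, with a range from 4000 nM to 19000 nM, the expected step being a 1.0-fold lower number from compound 2 to compound 3 (0.00 log units; within the scatter).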

Compound 3, half-maximal inhibitory concentration: > 10 nM
Compound 3 ended at the assay's limit; the forecaster's own chance of this, stated with the estimate: 10%; the middle value does not contradict the limit.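

In this assay compound 3 gives > 10 nM, which is a limit and not a number. The steps from compound 1 and from compound 2 to compound 3 cannot be read. The compounds shown leave open how 3,5-difluorophenyl compares with 3-chlorophenyl.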